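The compounds below may be only part of what the source reports. "The series", "measured", "known", "first", "only" and "open" are said of these compounds alone.

Measured in an in vitro ADME assay on microsomes (Homo sapiens) for metabolic stability; on this read-out higher numbers stand for fast clearance and lower numbers for slow clearance:
- Compound 1 `O=C(CN(C(=O)c1ccc(-c2ccccn2)cc1)C1CCCCC1)Nc1cc(F)cc(F)c1`: 5.2 mL.min-1.g-1
- Compound 2 `O=C(CN(C(=O)c1ccc(-c2ccccn2)cc1)C1CCOCC1)Nc1cc(F)cc(F)c1`: < 0.5 mL.min-1.g-1

Compound 2 gives < 0.5 mL.min-1.g-1, which is a limit of the assay and not a number. From the compounds shown here alone, it therefore stands at the limit of < 0.5 mL.min-1.g-1 in this assay, at which 1 of the 2 values shown sits, and its true clearance is unknown.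

Compound 3 `COCC(C)N(CC(=O)Nc1cc(F)cc(F)c1)C(=O)c1ccc(-c2ccccn2)cc1` carries 1-(methoxymethyl)ethyl in place of oxan-4-yl on an amide-type nitrogen. The ring is gone, but the group keeps its oxygen.

For the measured compounds named here, only one measured step bears on this place: an at least 10-fold lower number from compound 1 to compound 2 (1.01 log units; beyond the scatter). It was large and beyond the scatter, and it replaced cyclohexyl with oxan-4-yl. With the oxygen kept, a modest rise in this assay is expected, much smaller than that step, and the assay may again report only a limit.

The expected change is an at least 2.0-fold higher number from compound 2 to compound 3 (0.30 log units; that floor lies within the scatter). For compound 3 the estimate is 1 mL.min-1.g-1, with an expected range of 0.5 mL.min-1.g-1 to 3 mL.min-1.g-1.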

Compound 3, intrinsic clearance in microsomes: 5.8 mL.min-1.g-1
Compound 3: the middle estimate sits 5.8-fold (0.76 log units) below what was measured; the whole stated range lies below it.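

In this assay, keeping the oxygen while opening the ring does not hold the clearance down: the change to 1-(methoxymethyl)ethyl gives an at least 11-fold higher number from compound 2 to compound 3 (1.06 log units; beyond the scatter). Set against the all-carbon cyclohexyl, the same group gives a 1.1-fold higher number from compound 1 to compound 3 (0.05 log units; within the scatter), so at this position the open chain with its oxygen cannot be told apart from cyclohexyl, and an oxygen alone does not account for the low number of the oxan-4-yl group. Compound 2 stands at a limit and not a number, so how far the step from it truly reaches remains unknown: the limit of < 0.5 mL.min-1.g-1 in this assay, at which 1 of the 3 values shown sits.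

From the compounds shown here alone, whether the low clearance needs a ring of this size, or any ring that carries an oxygen, stays open. An oxetan-3-yl or a tetrahydrofuran-3-yl group would test this, and a piperidin-4-yl group would show whether a ring amine behaves the same way.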